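Changing the Benzyl Group on the Aromatic Nitrogen

The source may hold more compounds than are shown below. What is called first, only, known or untested is meant among the compounds shown, and "the series" means these compounds.

Three compounds have so far been measured in a functional assay on HepG2 cells (Homo sapiens) for antiproliferative activity, read by MTT assay, with a stated time of 72 h; a lower number here means a stronger inhibitor, a higher number a weaker inhibitor:

Compound 1, `COc1cccc(CNCc2c(C(=O)O)n(Cc3ccc(C)cc3)c3ccccc23)c1`, gives 14000 nM.
Compound 2, `COc1cccc(CNCc2c(C(=O)O)n(Cc3ccc(C)cc3)c3cc(C)ccc23)c1`, gives 5050 nM.
Compound 3, `COc1cccc(CNCc2c(C(=O)O)n(Cc3ccc(C)cc3)c3cc(C(C)C)ccc23)c1`, gives 3430 nM.

Compound 3 has the lowest number of the three. Its separation from compound 1 is clear: a 4.1-fold lower number from compound 1 to compound 3 (0.61 log units; beyond the scatter). Against compound 2, however, the step of a 1.5-fold lower number from compound 2 to compound 3 (0.17 log units; within the scatter) lies within the scatter, so compound 3 cannot be called stronger than compound 2 on these numbers. The step of a 2.8-fold lower number from compound 1 to compound 2 (0.44 log units; beyond the scatter) likewise lies beyond the scatter. All three steps concern the substituent on the aromatic carbon of the shared core.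

Compound 4, `COc1cccc(CNCc2c(C(=O)O)n(Cc3ccccc3F)c3cc(C(C)C)ccc23)c1`, is not yet measured. It differs from compound 3 in one place: 2-fluorophenyl in place of 4-methylphenyl on a saturated chain carbon bound to an aromatic nitrogen. Among the measured compounds shown here, none of the measured steps touches this part of the molecule; they leave the 4-methylbenzyl group unchanged throughout. For the measured compounds named here, there is therefore no measured step that bears on this change, and no ground in these data to expect a step in either direction beyond the scatter.

Compound 4 is accordingly expected to give about 3500 nM in this assay, with a range from 1400 nM to 9000 nM. That estimate means a step of a 1.0-fold higher number from compound 3 to compound 4 (0.01 log units; within the scatter), expected to stay within the scatter.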

Compound 4, half-maximal inhibitory concentration: 3300 nM
The estimate for compound 4 lay 1.1-fold (0.03 log units) above the measured number, within the range that was stated.
By their numbers in this assay, from the lowest: compounds 4, 3 and 2 (each within the scatter of the next); then compound 1.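

Among the compounds shown here, this is the first measured change to the group on the saturated chain carbon bound to an aromatic nitrogen, since the earlier steps altered only the substituent on an aromatic carbon of the shared core. With the isopropyl group held in place, the exchange of 4-methylbenzyl for 2-fluorobenzyl in this assay gives a 1.0-fold lower number from compound 3 to compound 4 (0.02 log units; within the scatter) and so leaves the two compounds indistinguishable, which shows that this one replacement of a methyl-bearing aromatic group by a fluorine-bearing one, with the same count of heavy atoms, does not move the number beyond the scatter. No measured evidence is available to explain this result.

On these data alone, whether the same exchange would hold with a hydrogen or a methyl group on the aromatic carbon, as in compound 1 and compound 2, remains open, since this single pair carries only the isopropyl group. Also open, as far as these compounds go, is how the number would respond at this position to a plain benzyl group, a longer alkyl chain or a chain ending in an amine, and to an ester or amide in place of the carboxylic acid on the shared core.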